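A few compounds are considered here, and "the series" means these few. Any claim that something is new, unique, unknown or untested is made for them only; others in the source may bear on it.

In a functional assay on HCT-116 cells (Homo sapiens) for cytotoxicity (a higher number here means a weaker inhibitor, a lower number a stronger inhibitor), compound 1 (`COc1cc(N2CCNCC2)ccc1Nc1nc(NC2CCCCC2)c2nc[nH]c2n1`) gives 88 nM. Compound 2 (`COc1cc(N2CCC(C(=O)N3CCC(N(C)C)C3)CC2)ccc1Nc1nc(NC2CCCCC2)c2nc[nH]c2n1`) gives 58 nM, which lies within the scatter of compound 1. Compound 3 (`COc1cc(N2CCC(CC(=O)N3CCOCC3)CC2)ccc1Nc1nc(NC2CCCCC2)c2nc[nH]c2n1`) gives 36 nM, a lower number than compound 1 and one beyond the scatter. Compound 4 (`CCN(CC)CC1CCN(c2ccc(Nc3nc(NC4CCCCC4)c4nc[nH]c4n3)c(OC)c2)CC1`) has not yet been measured. It differs from compound 1 as follows: 4-((diethylamino)methyl)piperidin-1-yl in place of piperazin-1-yl on an aromatic carbon. That is, 4-((diethylamino)methyl)piperidin-1-yl stands in place of piperazin-1-yl on an aromatic carbon. Going by the values given here, no measured step covers this exchange directly. Among the compounds with values here, the only single-place step available, a 1.6-fold lower number from compound 2 to compound 3 (0.21 log units; within the scatter), lies within the scatter and concerns a change further out on the substituent, so it bears on the question only indirectly. It does suggest that changes in that outer part have moved the number little. Compound 3, at 36 nM, also shows that a large group in this place can go with a lower number. A modest move toward lower numbers is therefore expected, with the estimated step, a 1.6-fold lower number from compound 1 to compound 4 (0.20 log units; within the scatter), staying within the scatter. Compound 4 is estimated at 55 nM, with an expected range of 20 nM to 140 nM.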

Compound 4, half-maximal inhibitory concentration: 74 nM
Estimate against measurement, compound 4: 1.3-fold (0.13 log units) below; low and high end bracket the measured number.
By their numbers in this assay, from the lowest: compounds 3, 2, 4 and 1 (each within the scatter of the next, the first and the last beyond it).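

In this assay, 4-((diethylamino)methyl)piperidin-1-yl, with 12 heavy atoms and 0 hydrogen-bond donors, stands in place of piperazin-1-yl, with 6 heavy atoms and 1 hydrogen-bond donor, on the aromatic carbon with a 1.2-fold lower number from compound 1 to compound 4 (0.08 log units; within the scatter) and so without a change beyond the scatter. The outer part of the substituent is not wholly indifferent, however: diethylamino in place of (morpholin-4-yl)carbonyl gives a 2.1-fold higher number from compound 3 to compound 4 (0.31 log units; beyond the scatter) as a modest step beyond the scatter, whereas the exchange with the (3-(dimethylamino)pyrrolidin-1-yl)carbonyl group gives a 1.3-fold higher number from compound 2 to compound 4 (0.11 log units; within the scatter) and stays within it. Nothing shown here explains these differences.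

The compounds shown leave open how an unsubstituted piperidine ring or a longer chain before the diethylamino group would read in this assay. They also leave open whether a carboxylic acid at the end of the substituent would be tolerated.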